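Methoxy to nitro on the aryl arm of the fused core

This account rests on a few compounds, and the source may have more. Where it says the series, first, only, none or still open, it means among the compounds named here.

Measured compounds:
compound 1 `CC(C)Cc1ccc(C(C)c2nnc3n2N=C(c2ccc(Cl)cc2)CS3)cc1` — 5700 nM
compound 2 `COc1ccc2cc(C(C)c3nnc4n3N=C(c3ccc(F)cc3)CS4)ccc2c1` — 7000 nM
compound 3 `COc1ccc(C2=Nn3c(nnc3C(C)c3ccc(-c4ccccc4)c(F)c3)SC2)cc1` — 4300 nM

All three were run in a functional assay on Huh-7 cells (Homo sapiens) for inhibition, read by sulforhodamine B assay, with a stated time of 72 h (a lower number here means a stronger inhibitor, a higher number a weaker inhibitor), and the numbers fall close together. Compound 3 holds the lowest of the three numbers, but its gap to compound 1 (5700 nM) and to compound 2 (7000 nM) both lie within the scatter, so no order among them can be read from this set.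

Compound 4 `CC(c1ccc(-c2ccccc2)c(F)c1)c1nnc2n1N=C(c1ccc([N+](=O)[O-])cc1)CS2` has not yet been measured. It differs from compound 3 in one place: nitro in place of methoxy on an aromatic carbon, a nitro in place of methoxy on an aromatic carbon, para to a large group. Among the compounds with values here, no pair of measured compounds differs at this position only, so nothing shows how this assay answers a change there; the halogen-bearing analogues compound 1 and compound 2 merely sit at the same level as compound 3. The step of a 1.0-fold higher number from compound 3 to compound 4 (0.02 log units; within the scatter) is therefore expected to be small, with no direction beyond the scatter. Compound 4 is estimated at 4500 nM, between 2000 nM and 10000 nM.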

Compound 4, half-maximal inhibitory concentration: 4300 nM
Compound 4: the middle estimate sits 1.0-fold (0.02 log units) above what was measured; low and high end bracket the measured number.
By their numbers in this assay, from the lowest: compounds 3, 4, 1 and 2 (each within the scatter of the next).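

In this assay, within the data shown here, the change from 4-methoxyphenyl to 4-nitrophenyl gives no change at the digits printed from compound 3 to compound 4 (within the scatter), the first direct reading at this position. With the rest of the molecule held constant, this place on the aromatic ring accepts either methoxy or nitro without a change that can be told from the scatter, although this single pair says nothing about other groups there. No measurement available here speaks to why the two groups read alike.

Still open, on these data alone, is whether an amine or a carboxylic acid in the same place would move the number beyond the scatter. Also open, as far as these compounds go, is whether the same exchange reads alike when the fluorinated biphenyl arm of compound 3 is replaced by another group.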